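The source may hold more compounds than are shown below. What is called first, only, known or untested is meant among the compounds shown, and "the series" means these compounds.

Compounds measured so far:
- compound 1, `Cc1nc(-c2cccc3ccccc23)sc1COc1ccc2c(c1)OCC2CC(=O)O`: "not determined" (no result reported) in a functional assay on CHO cells for agonist activity at Free fatty acid receptor 1 (Homo sapiens), read by FLIPR and calcium flux; on this read-out lower numbers stand for an effect already at smaller amounts and higher numbers for an effect only at larger amounts of compound
- compound 2, `Cc1cccc(-c2nc(C)c(COc3ccc4c(c3)OCC4CC(=O)O)s2)c1`: 119 nM

Going by the values given here, compound 2 is the only compound with a number in this assay; compound 1 carries no result. Compound 3, `Cc1ccc(-c2nc(C)c(COc3ccc4c(c3)OCC4CC(=O)O)s2)cc1`, has not been measured. It differs from compound 2 by a single change: 4-methylphenyl in place of 3-methylphenyl on an aromatic carbon. Among the compounds with values here, no step between measured compounds is available to gauge such a change, so the expectation rests on compound 2 alone. The step of a 1.3-fold higher number from compound 2 to compound 3 (0.10 log units; within the scatter) is expected to stay within the usual scatter, in neither direction. Compound 3 is therefore estimated to give 150 nM in this assay, with a range from 50 nM to 450 nM.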

Compound 3, half-maximal effective concentration: 73.5 nM
Compound 3: the middle estimate sits 2.0-fold (0.31 log units) above what was measured; low and high end bracket the measured number.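

With 4-methylphenyl in place of 3-methylphenyl on the aromatic carbon of the five-membered ring, this assay shows a 1.6-fold lower number from compound 2 to compound 3 (0.21 log units; within the scatter). Going by these compounds alone, this gives the first reading at this position: the two placements of the methyl group on the phenyl ring cannot be told apart on this read-out. Nothing measured here bears on this result.

As far as these compounds go, whether the methyl group contributes at all remains open, as a plain phenyl would show, and so does the effect of a different group on that ring, such as a chlorine, methoxy or trifluoromethyl.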